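A few compounds are considered here, and "the series" means these few. Any claim that something is new, unique, unknown or untested is made for them only; others in the source may bear on it.

In a functional assay on blood (Homo sapiens), with a stated time of 60 min, in the presence of a further agent that is not named here (a lower number here means that less compound is needed, a higher number that more compound is needed for the effect), compound 1 `O=C(Oc1ccccc1)C1(S(=O)(=O)c2ccc(Oc3ccc(OC(F)(F)F)cc3)cc2)CCC2(CCNCC2)C1` gives 900 nM. Compound 2 `CN(C)S(=O)(=O)NC(=O)C1(S(=O)(=O)c2ccc(Oc3ccc(OC(F)(F)F)cc3)cc2)CCC2(CCNCC2)C1` gives > 15000 nM, which is a limit of the assay and not a number. Its standing is therefore (the limit of > 15000 nM in this assay, at which 1 of the 2 values shown sits). Among the compounds with values here, the one measured step that bears on what follows is an at least 16-fold higher number from compound 1 to compound 2 (1.22 log units; beyond the scatter), with (dimethylsulfamoyl)amino in place of phenoxy on a carbonyl carbon. Compound 3 `COc1ccc(N)c(NC(=O)C2(S(=O)(=O)c3ccc(Oc4ccc(OC(F)(F)F)cc4)cc3)CCC3(CCNCC3)C2)c1` has 2-amino-5-methoxyphenyl in place of dimethylsulfamoyl on an amide-type nitrogen. Within the data shown here, the measured step shows that a change on this side of the carbonyl can move the number a long way, although no measured step tests the entering group itself. Compound 1 gives 900 nM with an aromatic ring on this side, and compound 3 also has one, so a partial return towards a lower number in this assay is expected. The estimated change is an at least 3.0-fold lower number from compound 2 to compound 3 (0.47 log units; beyond the scatter), and this size is uncertain. For compound 3 the expected value is 5000 nM, with an estimated range from 1200 nM to 15000 nM.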

Compound 3, half-maximal effective concentration: 3700 nM
Estimate against measurement, compound 3: 1.4-fold (0.13 log units) above; the measured number falls inside the stated range.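

In this assay, the amide-type nitrogen can carry an aromatic ring and still give a number inside the range of the assay, with an at least 4.0-fold lower number from compound 2 to compound 3 (0.60 log units; beyond the scatter). The true size of this step is open on one side, as compound 2 stands at a limit of the assay and not at a number: the limit of > 15000 nM in this assay, at which 1 of the 3 values shown sits. An aromatic ring on this side of the carbonyl is still not enough to match the phenoxy group, as the swap of phenoxy for (2-amino-5-methoxyphenyl)amino on the carbonyl carbon gives a 4.1-fold higher number from compound 1 to compound 3 (0.61 log units; beyond the scatter).

The compounds shown leave open which part of the 2-amino-5-methoxyphenyl group accounts for the step from the dimethylsulfamoyl group: the ring itself, its amino group or its methoxy group. They also do not tell how a plain phenyl group or a pyridine ring on the amide-type nitrogen would read in this assay, or whether either would come closer to the number of the phenoxy compound.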